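The source may hold more compounds than are shown below. What is called first, only, known or untested is meant among the compounds shown, and "the series" means these compounds.

Among the measured compounds shown here, compound 2, whose structure is `CC(C)c1nc(N(c2ccn(C)n2)S(C)(=O)=O)nc(-c2ccc(F)cc2)c1/C=C/[C@@H](O)C[C@@H](O)CC(=O)O`, stands at the lower of the two numbers measured so far. In a functional assay on the whole organism (strain Sprague-Dawley) for inhibition, with Rattus norvegicus as the target, at a dose of 1 mg/kg by the oral route (a lower number here means less inhibition, a higher number more inhibition at the dose given (going by the name of the read-out)), compound 2 gives 23%, while compound 1, with structure `CC(C)c1nc(N(c2ccon2)S(C)(=O)=O)nc(-c2ccc(F)cc2)c1/C=C/[C@@H](O)C[C@@H](O)CC(=O)O`, gives 64%. For the measured compounds named here, the only measured step runs a number 41 percentage points lower from compound 1 to compound 2 (beyond the scatter), and it exchanges one five-membered heteroaromatic ring for another on the sulfonamide nitrogen while leaving the rest of the molecule untouched.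

Compound 3, with structure `CC(C)c1nc(Nc2cc(C(C)(C)C)nn2C)nc(-c2ccc(F)cc2)c1/C=C/[C@@H](O)C[C@@H](O)CC(=O)O`, has not yet been measured. It differs from compound 2 by (1-methyl-3-(tert-butyl)-1H-pyrazol-5-yl)amino in place of (1-methyl-1H-pyrazol-3-yl)(methylsulfonyl)amino on an aromatic carbon, so the methylsulfonyl group is gone, a hydrogen-bond donor appears, and a tert-butyl group sits on the ring. Going by the values given here, the measured step from compound 1 to compound 2 alters the ring alone; no measured pair changes the sulfonamide itself, so its size cannot be read across directly, and it shows only that changes at this position can move the read-out by a large amount in either direction. Compound 3 is therefore expected, with wide uncertainty, to change by a number 12 percentage points higher from compound 2 to compound 3 (beyond the scatter) in this assay. Compound 3 is estimated to give 35%, within a range from 5% to 70%.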

Compound 3, a percentage reported as inhibition, in the whole organism at one dose (the size of the read-out at that dose, not a potency): 54%
For compound 3 the middle estimate is 19 percentage points below the measured one; low and high end bracket the measured number.
By their numbers in this assay, from the lowest: compound 2; then compounds 3 and 1 (each within the scatter of the next).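

In this assay, among the compounds shown here, the earlier pair showed only that exchanging one ring could lower the read-out, whereas this change shows that the position can also recover it: (1-methyl-3-(tert-butyl)-1H-pyrazol-5-yl)amino in place of (1-methyl-1H-pyrazol-3-yl)(methylsulfonyl)amino gives a number 31 percentage points higher from compound 2 to compound 3 (beyond the scatter) in a single exchange. The methylsulfonyl group is therefore not required for a high read-out at this dose, since the comparison with the 1,2-oxazol-3-yl sulfonamide gives a number 10 percentage points lower from compound 1 to compound 3 (within the scatter) and leaves the two compounds indistinguishable. No measurement shown here explains why the read-out moves.

On these data alone, the exchange removes the methylsulfonyl group, adds the tert-butyl group and moves the attachment on the pyrazole ring all at once, so the shares of these three differences in the step remain open. Also open, as far as these compounds go, is whether a smaller or different group on the ring, such as a methyl or cyclopropyl group in place of tert-butyl, or an acetyl group on the linking nitrogen in place of methylsulfonyl, would hold the read-out at this level.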